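Ring swap at the thiocarbonyl carbon: outlook for compound 4

The compounds below may be only part of what the source reports. "The series", "measured", "known", "first", "only" and "open" are said of these compounds alone.

Compound 1 `CCN1CCN(C(=S)SCC(O)Cn2c([N+](=O)[O-])cnc2C)CC1` is the reference point of the series. In a toxicity assay on HeLa cells (Homo sapiens) for cytotoxicity, read by MTT assay, with a stated time of 24 h (on this read-out lower numbers stand for stronger inhibition and higher numbers for weaker inhibition), compound 1 gives > 5000000 nM, which is a limit of the assay and not a number. Compound 2 `Cc1ncc([N+](=O)[O-])n1CC(O)CSC(=S)N1CCN(c2ccccc2)CC1` carries phenyl in place of ethyl on the amine nitrogen in the ring. In this assay compound 2 gives > 5000000 nM, again a limit of the assay. Compound 3 `Cc1ncc([N+](=O)[O-])n1CC(O)CSC(=S)N1CCN(c2ccccc2F)CC1` carries 2-fluorophenyl at that nitrogen, and in this assay compound 3 gives 3240000 nM. Where compound 1 stands is thus known only as a limit; the limit of > 5000000 nM in this assay, at which 2 of the 3 values shown sit, is where two of the three values sit. The readable steps are an at least 1.5-fold lower number from compound 1 to compound 3 (0.18 log units; that floor lies within the scatter) and an at least 1.5-fold lower number from compound 2 to compound 3 (0.18 log units; that floor lies within the scatter), each only a floor lying within the scatter, while a step that the two limits leave unreadable from compound 1 to compound 2.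

Compound 4 `Cc1ncc([N+](=O)[O-])n1CC(O)CSC(=S)N1CCCCCC1` differs from compound 1 by azepan-1-yl in place of 4-ethylpiperazin-1-yl on a thiocarbonyl carbon. Among the measured compounds shown here, none of the measured steps touches the ring on the thiocarbonyl carbon; all three vary the substituent on the amine nitrogen in the ring. For the measured compounds named here, no measured step therefore bears on this change, and nothing beyond the scatter is expected in this assay. The step from compound 1 to compound 4 is expected to be a number no higher from compound 1 to compound 4 (the limit leaves the size open). Compound 4 is estimated at 5000000 nM, within 2000000 nM to 15000000 nM, with a fair chance that only a limit is returned once more.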

Compound 4, half-maximal inhibitory concentration: 411000 nM
Compound 4: middle estimate off by 12-fold (1.09 log units), on the high side; measured number below the stated range.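

Among the compounds shown here, of the steps in this assay, this is the first clearly readable one, and it falls at the ring on the thiocarbonyl carbon, not at the amine nitrogen in the ring that the earlier compounds varied: an at least 12-fold lower number from compound 1 to compound 4 (1.08 log units; beyond the scatter). Those earlier steps gave only floors within the scatter or could not be read, so the ring on the thiocarbonyl carbon now stands as a place in the series where the read-out moves. The size printed for this step remains a floor and not a measured gap, because compound 1 is held only as a limit of the assay: the limit of > 5000000 nM in this assay, at which 2 of the 4 values shown sit.

The step swaps one six-membered non-aromatic ring with 2 hetero atoms for one seven-membered non-aromatic ring with 1 hetero atom and also loses the ethyl, so ring size, the second ring nitrogen and the substituent on it all change at once, and the compounds shown cannot separate them. As far as these compounds go, a piperidine ring on the thiocarbonyl carbon would keep the six-membered size with a single nitrogen, and a morpholine ring would put an oxygen in place of the second nitrogen; how either reads remains open.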